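Aryl swap on the shared core: chloro to trifluoromethyl

The source may report more compounds than this note shows. Statements on the series, on what has been measured and on what is new or still open speak of the compounds shown alone.

Compound 1 `CC(=O)c1ccc(-c2cn3ccnc3c(-c3ccc4ncn(C5CCCCC5)c4c3)n2)cc1` in a functional assay on KM12 cells (Homo sapiens) for inhibition, read by sulforhodamine B assay, with a stated time of 48 h, tested at 10 uM (on this read-out higher numbers stand for more inhibition at the one concentration tested (going by the name of the read-out) and lower numbers for less inhibition), gives 11.7%. Among the measured compounds shown here, compound 2 `Clc1ccc(-c2cn3ccnc3c(-c3ccc4ncn(C5CCCCC5)c4c3)n2)cc1` in this assay gives 10.6%; compound 2 stands alongside compound 1, the two numbers within the scatter of each other, and the single measured step, a number 1.1 percentage points lower from compound 1 to compound 2 (within the scatter), is within the scatter. Compound 3 `FC(F)(F)c1cccc(-c2cn3ccnc3c(-c3ccc4ncn(C5CCCCC5)c4c3)n2)c1` carries 3-(trifluoromethyl)phenyl in place of 4-chlorophenyl on an aromatic carbon. For the measured compounds named here, no measured step covers this exact pair; the one step at the same position stayed within the scatter, so for compound 3 no move beyond the scatter in this assay is expected. Compound 3 is estimated at 11%, range 0% to 28%, an expected step of a number 0.4 percentage points higher from compound 2 to compound 3 (within the scatter).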

Compound 3, a percentage reported as inhibition, at one concentration (the size of the read-out at that concentration, not a potency): 1.25%
The estimate for compound 3 lay 9.8 percentage points above the measured number, and the stated range covers the measured number.
By their numbers in this assay, from the lowest: compounds 3, 2 and 1 (each within the scatter of the next, the first and the last beyond it).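

In this assay, changing the aryl group at this position can move the number beyond the scatter (a number 10.5 percentage points lower from compound 1 to compound 3 (beyond the scatter)), which the step from compound 1 to compound 2 did not do. The change from 4-chlorophenyl stays within the scatter (a number 9.4 percentage points lower from compound 2 to compound 3 (within the scatter)), so only the contrast with 4-acetylphenyl can be read as a change. Nothing measured here accounts for that difference.

On these data alone, whether it goes with the trifluoromethyl group or with its place on the phenyl ring stays open. So does the outcome with an amine or a carboxylic acid on that ring.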